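Dropping a Methoxy From a Weak Antiproliferative Scaffold

The source may report more compounds than this note shows. Statements on the series, on what has been measured and on what is new or still open speak of the compounds shown alone.

Measured compounds:
Compound 1 `N#Cc1c(-c2ccc(F)cc2)nc2c(c(-c3ccccc3)nn2-c2ccccc2)c1-c1ccc(O)cc1`: > 25000 nM
Compound 2 `COc1cc(-c2c(C#N)c(-c3cccs3)nc3c2c(-c2ccccc2)nn3-c2ccccc2)ccc1O`: 37300 nM

Among the compounds with values here, in a functional assay on CCRF-CEM cells (Homo sapiens) for antiproliferative activity, read by resazurin assay, with a stated time of 72 h (a higher number here means a weaker inhibitor, a lower number a stronger inhibitor), compound 2 gives 37300 nM, the only full number among the values shown. Compound 1 reaches only a limit of this assay, > 25000 nM, and (the limit of > 25000 nM in this assay, at which 1 of the 2 values shown sits). Compound 3 `N#Cc1c(-c2cccs2)nc2c(c(-c3ccccc3)nn2-c2ccccc2)c1-c1ccc(O)cc1` differs from compound 2 by hydrogen in place of methoxy on an aromatic carbon. Within the data shown here, no measured pair shows this same change, so no size of step can be read from the measured compounds; a step no larger than the usual scatter, in either direction, is what is expected. Compound 3 is therefore expected to give about 32000 nM, between 10000 nM and 100000 nM, an expected change of a 1.2-fold lower number from compound 2 to compound 3 (0.07 log units; within the scatter).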

Compound 3, half-maximal inhibitory concentration: > 25000 nM
Compound 3 gave a limit, no number (the forecaster's own chance of this, stated with the estimate: 45%); the middle value lies beyond the limit too.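

Within the data shown here, no step to compound 3 can be read, neither from compound 2 nor from compound 1, because the comparison ends at a limit: the limit of > 25000 nM in this assay, at which 2 of the 3 values shown sit. Going by these compounds, whether hydrogen in place of methoxy, or thiophen-2-yl in place of 4-fluorophenyl, changes antiproliferative activity at all stays open.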